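The source may report more compounds than this note shows. Statements on the series, on what has been measured and on what is new or still open speak of the compounds shown alone.

Measured so far in a functional assay for inhibition, with Homo sapiens as the target; a higher number here means a weaker inhibitor, a lower number a stronger inhibitor:
compound 1 `CCc1ccc(Nc2nccc(-c3ccncc3)n2)cc1` gives 7700 nM;
compound 2 `CC1CCN(c2ccc(Nc3nccc(-c4ccncc4)n3)cc2)CC1` gives 600 nM;
compound 3 `Oc1ccc(Nc2nccc(-c3ccncc3)n2)cc1` gives 3300 nM.

Compound 1 has the highest number of the three and is therefore the weakest inhibitor here; the nearest is compound 3, as a 2.3-fold lower number from compound 1 to compound 3 (0.37 log units; beyond the scatter) shows, and the furthest is compound 2, with a 13-fold lower number from compound 1 to compound 2 (1.11 log units; beyond the scatter). Compound 4 `CCc1ccc(Nc2nccc(-c3cc(C)oc3C)n2)cc1` differs from compound 1 in one place: 2,5-dimethylfuran-3-yl in place of pyridin-4-yl on an aromatic carbon. Both measured steps alter the ethyl side of the shared core, so neither bears on a change at the place where the pyridin-4-yl sits, and no guide to its size or direction exists among these compounds. Compound 4 is therefore expected to lie near compound 1, at an estimated 15000 nM, within 4000 nM to 60000 nM, an expected step of a 1.9-fold higher number from compound 1 to compound 4 (0.29 log units; within the scatter).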

Compound 4, half-maximal inhibitory concentration: 19200 nM
Beside the measured number, compound 4's estimate is 1.3-fold (0.11 log units) below it, and the stated range covers the measured number.
By their numbers in this assay, from the lowest: compound 2; then compound 3; then compound 1; then compound 4.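

Among the compounds shown here, the first change at the place held by pyridin-4-yl shows that this position affects the result in this assay: 2,5-dimethylfuran-3-yl modestly weakens inhibition (a 2.5-fold higher number from compound 1 to compound 4 (0.40 log units; beyond the scatter)). The swap alters several things at once, replacing a six-membered aromatic ring with a five-membered one, exchanging the hetero atom and adding two methyl groups, so the step cannot be assigned to any one of them. No measurement here explains the weakening.

Open, on these data alone, is whether furan-3-yl without its methyl groups or pyridin-3-yl would stay closer to compound 1. Also open, as far as these compounds go, is whether the 4-methylpiperidin-1-yl of compound 2 would bring the same gain alongside 2,5-dimethylfuran-3-yl.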